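The source may hold more compounds than are shown below. What is called first, only, known or untested is meant among the compounds shown, and "the series" means these compounds.

The compounds share one core. Compound 1 `Cc1cc(C(=O)Nc2ccc(-c3ccccc3S(N)(=O)=O)cc2)n(-c2cccc(N)c2)n1` carries a 3-aminophenyl group on an aromatic nitrogen of that core. In an assay on isolated protein for inhibition of Trypsin (Homo sapiens) (a higher number here means a weaker inhibitor, a lower number a stronger inhibitor), compound 1 gives > 1600 nM, which is a limit of the assay rather than a number. Compound 2 `Cc1cc(C(=O)Nc2ccc(-c3ccccc3S(N)(=O)=O)cc2)n(-c2ccc3c(N)[nH]nc3c2)n1` carries a 3-amino-2H-indazol-6-yl group in the same place. In this assay compound 2 gives > 1600 nM, again a limit of the assay and not a number. The step that the two limits leave unreadable from compound 1 to compound 2 cannot be read from the two values, since both sit at the same limit (the limit of > 1600 nM in this assay, at which 2 of the 2 values shown sit), so compound 2 stands only at that limit, with no number to place it more exactly.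

Compound 3 `Cc1cc(C(=O)Nc2ccc(-c3ccccc3S(N)(=O)=O)cc2)n(-c2ccc3nc(N)nc(N)c3c2)n1` differs from compound 2 by 2,4-diaminoquinazolin-6-yl in place of 3-amino-2H-indazol-6-yl on an aromatic nitrogen. For the measured compounds named here, only one measured step touches this kind of change, and its size is unreadable, so the measurements give no direction and no size to expect in this assay. The step that the limit leaves unreadable from compound 2 to compound 3 is therefore an estimate made with little support. Compound 3 is expected to give about 3000 nM, between 300 nM and 20000 nM, with a real chance that only a limit is reported once more.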

Compound 3, inhibition constant: > 1600 nM
Compound 3 ended at the assay's limit; the forecaster's own chance of this, stated with the estimate: 55%; the middle value is on the limit's open side.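

In this assay compound 3 gives > 1600 nM as a limit of the assay and not a number. The steps to compound 3 from compound 1 and from compound 2 cannot be read, since all the values sit at one limit: the limit of > 1600 nM in this assay, at which 3 of the 3 values shown sit. How strongly any of these compounds inhibits, and whether their groups on the aromatic nitrogen differ at all, stays open.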